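Tert-butyl for bromo on the carbonyl-linked ring of compound 2

The compounds below may be only part of what the source reports. "The series", "measured", "known", "first", "only" and "open" are said of these compounds alone.

For the measured compounds named here, compound 2 `COc1cc(N(Cc2nc3ccccc3[nH]2)C(=O)c2ccc(Br)cc2)cc(OC)c1OC` carries the (4-bromophenyl)carbonyl group on the ring nitrogen; in a functional assay on MGC-803 cells (Homo sapiens) for inhibition, read by MTT assay, with a stated time of 48 h (on this read-out higher numbers stand for weaker inhibition and lower numbers for stronger inhibition), compound 2 gives 14600 nM, the highest number of the two measured so far. Going by the values given here, its sulfonyl counterpart, compound 1 `COc1cc(N(Cc2nc3ccccc3[nH]2)S(=O)(=O)c2ccc(Br)cc2)cc(OC)c1OC`, gives 2190 nM in this assay, and the single measured step, a 6.7-fold higher number from compound 1 to compound 2 (0.82 log units; beyond the scatter), concerns only the exchange of sulfonyl for carbonyl on that nitrogen. Compound 3 `COc1cc(N(Cc2nc3ccccc3[nH]2)C(=O)c2ccc(C(C)(C)C)cc2)cc(OC)c1OC` keeps the carbonyl of compound 2 and differs from it in one place: tert-butyl in place of bromo on an aromatic carbon. Among the compounds with values here, no measured pair shows this exchange, nor any other change on that six-membered ring; the one step in hand speaks to the linking group and carries no information on the substituent at the far end of the ring. The expectation for compound 3 therefore rests on compound 2 alone, with nothing in the data to push it either way. For compound 3 the step of no change at the digits printed from compound 2 to compound 3 (within the scatter) is estimated as no shift beyond the scatter. Compound 3 is accordingly expected to give 14600 nM in this assay, with a range from 5000 nM to 42000 nM.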

Compound 3, half-maximal inhibitory concentration: > 50000 nM
Compound 3 gave a limit, no number; the forecaster's own chance of this, stated with the estimate: 10%; middle value at least 3.4-fold (0.53 log units) away from the limit.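

The reading for compound 3 is a limit of the assay and not a number: the limit of > 50000 nM in this assay, at which 1 of the 3 values shown sits.

Tert-butyl in place of bromo, on an aromatic carbon para to a large group, gives an at least 3.4-fold higher number from compound 2 to compound 3 (0.53 log units; beyond the scatter) in this assay, so the change moves the read-out towards weaker inhibition by an amount beyond the scatter, and how far it moves stays open on the upper side. For the compounds shown here, this is the first sign that the far end of this six-membered ring matters in the carbonyl-linked compounds: the earlier pair spoke only to the linking group, whereas the substituent on the ring now proves to count as well, with bromo the better of the two groups seen here.

Whether tert-butyl costs as much with the sulfonyl link of compound 1 remains open, since the compounds shown hold this exchange on the carbonyl link alone. Also open, going by these compounds, is how an amine or a carboxylic acid on this aromatic carbon would read, and so whether the response at this position follows the size of the group or something else.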